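This account rests on a few compounds, and the source may have more. Where it says the series, first, only, none or still open, it means among the compounds named here.

In a functional assay on BXPC-3 cells (Homo sapiens) for antiproliferative activity, read by MTT assay, with a stated time of 24 h (on this read-out lower numbers stand for stronger inhibition and higher numbers for weaker inhibition), compound 1 `CCn1c(C(=O)NCCNC(=O)OC(C)(C)C)ccc1C(CC)(CC)c1ccc(OCS(=O)(=O)c2ccccc2)c(C)c1` gives > 50000 nM as a limit of the assay and not a number. Within the data shown here, compound 2 `CCn1c(C(=O)N[C@H](C)CO)ccc1C(CC)(CC)c1ccc(OCS(=O)(=O)c2ccccc2)c(C)c1` gives 10000 nM in this assay as the only true number so far. Among the measured compounds shown here, the only measured step is an at least 5.0-fold lower number from compound 1 to compound 2 (0.69 log units; beyond the scatter) and it puts 1-(hydroxymethyl)ethyl in place of 2-((tert-butoxycarbonyl)amino)ethyl on an amide-type nitrogen. From the compounds shown here alone, one end of that step is a limit, so its full size stays open.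

Compound 3 `CCn1c(C(=O)NC(C)(C)CO)ccc1C(CC)(CC)c1ccc(OCS(=O)(=O)c2ccccc2)c(C)c1` changes the same place, and the difference 1-(hydroxymethyl)-1-methylethyl in place of 1-(hydroxymethyl)ethyl on an amide-type nitrogen is 1-(hydroxymethyl)-1-methylethyl in place of 1-(hydroxymethyl)ethyl. This is a much smaller swap than the measured one, since the hydroxymethyl stays and a methyl enters. Compound 2 at 10000 nM is therefore the natural anchor, and the step of an at least 5.0-fold lower number from compound 1 to compound 2 (0.69 log units; beyond the scatter) gives no reason to expect a jump of similar size. The expected change in this assay is a 1.2-fold higher number from compound 2 to compound 3 (0.08 log units; within the scatter) and no shift beyond the usual scatter is expected. For compound 3 the estimated value is 12000 nM with an expected range from 4500 nM to 40000 nM in this measurement.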

Compound 3, half-maximal inhibitory concentration: 18300 nM
Beside the measured number, compound 3's estimate is 1.5-fold (0.18 log units) below it, and the stated range covers the measured number.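

Putting 1-(hydroxymethyl)-1-methylethyl in place of 1-(hydroxymethyl)ethyl on the amide-type nitrogen gives a 1.8-fold higher number from compound 2 to compound 3 (0.26 log units; within the scatter), so in this assay these two compounds cannot be told apart. This position therefore accepts one more carbon and the loss of the defined stereocentre with no change beyond the usual scatter, at least within this small pair. Replacing 2-((tert-butoxycarbonyl)amino)ethyl with the new group gives an at least 2.7-fold lower number from compound 1 to compound 3 (0.43 log units; beyond the scatter), so a second hydroxymethyl-bearing group also reads lower than the group in compound 1, whose value is a limit of the assay and not a number: the limit of > 50000 nM in this assay, at which 1 of the 3 values shown sits.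

The compounds shown leave open whether the hydroxyl itself matters, a question that a plain tert-butyl group on the same nitrogen, or a free primary amine such as 2-aminoethyl, would address directly. They also leave open how a longer chain such as 3-hydroxypropyl, a carboxylic acid at the end of the chain, or the mirror-image form of 1-(hydroxymethyl)ethyl would read in this assay.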